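Bromo for chloro on two cores

The source may hold more compounds than are shown below. What is called first, only, known or untested is meant among the compounds shown, and "the series" means these compounds.

Measured in a physicochemical assay for lipophilicity, using the shake flask method, in phosphate buffer, measured as octanol-water partition, with a stated time of 40 min, at pH 7.4; a higher number here means a more lipophilic compound, a lower number a more polar compound:
compound 1 `COc1cc(Cl)c(Nc2nc(Cl)cn([C@@H](COCCF)C3CC3)c2=O)c(Cl)c1` gives 4
compound 2 `COc1cc(Cl)c(Nc2nc(Br)cn([C@@H](COCCF)C3CC3)c2=O)c(Cl)c1` gives 4.1
compound 3 `COc1nc(Cl)nc(C)c1Nc1nc(Cl)cn([C@@H](COCCF)C2CC2)c1=O` gives 3.3

Compounds 1 and 2 share one core; compound 3 and the unmeasured compound 4 `COc1nc(Cl)nc(C)c1Nc1nc(Br)cn([C@@H](COCCF)C2CC2)c1=O` share another. The difference between the two cores is not broken down here. In this assay compound 3 stands lowest of the three, with both compound 1 and compound 2 beyond the scatter above it; compound 1 and compound 2 themselves lie within the scatter of each other.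

The change made on the first core, (bromo in place of chloro on an aromatic carbon), gave a number 0.10 log units higher from compound 1 to compound 2 (within the scatter), a step within the scatter. The change planned on the second core, (bromo in place of chloro on an aromatic carbon), is the same change: the place is described in the same words, and the group that leaves and the group that enters are the same. Within the data shown here, on that basis the expected step is a number 0.10 log units higher from compound 3 to compound 4 (within the scatter), resting on the single earlier step of a number 0.10 log units higher from compound 1 to compound 2 (within the scatter) and on the value of compound 3 in this assay, 3.3. Compound 4 is therefore estimated at 3.4, expected between 3.1 and 3.7.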

Compound 4, distribution coefficient: 3.4
Compound 4: middle estimate and measured number agree at the digits printed, within the range that was stated.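

In this assay bromo in place of chloro on an aromatic carbon gives a number 0.10 log units higher from compound 3 to compound 4 (within the scatter) on the second core, against a number 0.10 log units higher from compound 1 to compound 2 (within the scatter) on the first, so the two steps agree in size and neither goes beyond the scatter. This shows that, for these two pairs, the exchange carries from one core to the other with the same small step; it does not show that the same would hold on any further core in the series, since two pairs are all that stand behind it, and a step within the scatter cannot separate a small real shift from none. Nothing available bears on why the two steps agree.

Going by these compounds, whether the agreement between cores would extend to a nitrile, an amine or a carboxylic acid at this place stays open. Also open, on these data alone, is whether a longer chain in place of the 1-cyclopropyl-2-(2-fluoroethoxy)ethyl group would leave the step as it stands.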